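A few compounds are considered here, and "the series" means these few. Any claim that something is new, unique, unknown or untested is made for them only; others in the source may bear on it.

Compound 1 `O=C(NCCCN1CCN(CCCNc2ccnc3cc(Cl)ccc23)CC1)c1cccc(C(F)(F)F)c1` carries a 3-(trifluoromethyl)phenyl on the carbonyl carbon of its amide. Going by the values given here, in an ADME assay on L6 cells (Rattus norvegicus) for cytotoxicity (a higher number here means a weaker inhibitor, a lower number a stronger inhibitor), compound 1 gives 30100 nM, the highest of the two numbers known, and its nearest neighbour is compound 2 `O=C(NCCCN1CCN(CCCNc2ccnc3cc(Cl)ccc23)CC1)c1cc(Cl)cc(Cl)c1`, which in this assay gives 3000 nM. Among the compounds with values here, the one step known is a 10-fold lower number from compound 1 to compound 2 (1.00 log units; beyond the scatter); it is the only exchange of the aryl group on that carbonyl carbon for which both numbers exist.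

Compound 3 `O=C(NCCCN1CCN(CCCNc2ccnc3cc(Cl)ccc23)CC1)c1ccc(Cl)c([N+](=O)[O-])c1` differs from compound 1 at that same place: 4-chloro-3-nitrophenyl in place of 3-(trifluoromethyl)phenyl on a carbonyl carbon. The measured step bears on this change only in that it also replaces the 3-(trifluoromethyl)phenyl on the carbonyl carbon, and there the number fell by a modest amount; the group entering in compound 3 is not the 3,5-dichlorophenyl of compound 2, so a smaller move is expected. For compound 3 the expected step is a 3.0-fold lower number from compound 1 to compound 3 (0.48 log units; beyond the scatter), a lower number than compound 1 but not reaching compound 2. Compound 3 is therefore estimated at 10000 nM, with a range from 3000 nM to 30000 nM.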

Compound 3, half-maximal inhibitory concentration: 11300 nM
The estimate for compound 3 lay 1.1-fold (0.05 log units) below the measured number; measured number inside the range.
By their numbers in this assay, from the lowest: compound 2; then compound 3; then compound 1.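

In this assay, a second replacement of the 3-(trifluoromethyl)phenyl on the carbonyl carbon moves the number in the same direction as the first, a 2.7-fold lower number from compound 1 to compound 3 (0.43 log units; beyond the scatter), so compound 1 now has the highest number against two different partners rather than one. The new comparison, a 3.8-fold higher number from compound 2 to compound 3 (0.58 log units; beyond the scatter), shows that this place also separates two aryl groups that both carry chlorine, and the step from compound 1 to compound 3 shows that the number can shift between groups with equal heavy-atom counts and the same kind of ring. No measurement is at hand that explains either step or the order of the three compounds.

The three aryl groups differ in more than one substituent at a time, so the shares of the chlorine, the nitro group and the trifluoromethyl group in these steps cannot be separated. As far as these compounds go, it also remains open how the number would respond to an unsubstituted phenyl, to a ring carrying a single chlorine, a nitrile or an amine, or to a change anywhere else in the shared core.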